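The source may report more compounds than this note shows. Statements on the series, on what has been measured and on what is new or still open speak of the compounds shown alone.

Compound 1 `CCCCOC(=O)NS(=O)(=O)c1sc(CC(C)C)cc1-c1ccc(Cn2cccn2)cc1` gives 2.3 nM in an assay on membranes from uterus for displacement of a labelled ligand from Angiotensin type II receptor (Sus scrofa), with a stated time of 1.5 h; a lower number here means a stronger inhibitor, a higher number a weaker inhibitor; compound 2 `CCCCOC(=O)NS(=O)(=O)c1sc(CC(C)C)cc1-c1ccc(Cc2nnc(C(F)(F)F)o2)cc1` gives 328 nM in this assay.

Within the data shown here, compound 2 has the highest number of the two; the only measured step, a 140-fold higher number from compound 1 to compound 2 (2.15 log units; beyond the scatter), shows how far it lies from compound 1. Compound 3 `CCCCOC(=O)NS(=O)(=O)c1sc(CC(C)C)cc1-c1ccc(C(=O)c2ccnn2C)cc1` is not yet measured. It differs from compound 2 as follows: a group of 8 heavy atoms (5 carbon, 2 nitrogen, 1 oxygen; one five-membered aromatic ring with 2 hetero atoms) in place of a group of 10 heavy atoms (4 carbon, 2 nitrogen, 1 oxygen, 3 fluorine; one five-membered aromatic ring with 3 hetero atoms), on an aromatic carbon. The group entering carries a pyrazole ring again, which compound 1 also carries, so the large step from compound 1 to compound 2 bears on this change in reverse, although the carbonyl link is new. Compound 3 is therefore expected to give a markedly lower number, a step of a 16-fold lower number from compound 2 to compound 3 (1.21 log units; beyond the scatter), with an estimate of 20 nM, between 3 nM and 150 nM.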

Compound 3, inhibition constant: 3.4 nM
For compound 3 the middle estimate is 5.9-fold (0.77 log units) above the measured one; low and high end bracket the measured number.
By their numbers in this assay, from the lowest: compounds 1 and 3 (each within the scatter of the next); then compound 2.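

Replacing the oxadiazole group with (1-methyl-1H-pyrazol-5-yl)carbonyl in this assay gives a 96-fold lower number from compound 2 to compound 3 (1.98 log units; beyond the scatter) and so recovers nearly all of the earlier loss. The comparison with the first pyrazole compound gives a 1.5-fold higher number from compound 1 to compound 3 (0.17 log units; within the scatter), so on this aromatic carbon a pyrazole with a carbonyl link matches a pyrazole with a methylene link. No measurement here explains this recovery.

On these data alone, whether the ring, the trifluoromethyl group or the link matters most stays open. So does how an amine or a carboxylic acid would fare at this position.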